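The compounds below may be only part of what the source reports. "The series", "measured", "known", "first", "only" and "open" are said of these compounds alone.

Series read in a functional assay on the whole organism (stomach) for inhibition, with Rattus norvegicus as the target, at a dose of 100 mg/kg by the intraduodenal route; on this read-out lower numbers stand for less inhibition and higher numbers for more inhibition at the one dose given (going by the name of the read-out):

compound 1 `C/N=C(\S)CCn1nc(-c2ccccc2)ccc1=O` gives 68.2%
compound 2 `C/N=C(\S)CCn1ncccc1=O` gives 35.7%
compound 3 `COc1ccc(-c2ccc(=O)n(CCC(=N)S)n2)cc1` gives 20.7%

Compound 1 stands highest of the three numbers in this assay. The nearest is compound 2, reached by a number 32.5 percentage points lower from compound 1 to compound 2 (beyond the scatter). Compound 3 lies further below, but compound 3 differs from compound 1 in more than one place, so only the two values themselves can be compared there.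

Compound 4 `N=C(S)Cn1nc(-c2ccccc2)ccc1=O` is not yet measured. Relative to compound 1 the change is a group of 3 heavy atoms (1 carbon, 1 nitrogen, 1 sulfur; no ring) in place of a group of 5 heavy atoms (3 carbon, 1 nitrogen, 1 sulfur; no ring), on a saturated chain carbon bound to an aromatic nitrogen. Within the data shown here, the single measured step, a number 32.5 percentage points lower from compound 1 to compound 2 (beyond the scatter), concerns the phenyl on an aromatic carbon and leaves the chain untouched, so no measured step bears directly on this change. Compound 3 carries the group that enters, but on a longer chain and with a further change on the aromatic carbon, so its value and that of compound 1 cannot be separated into the two changes. Without direct precedent, a moderate drop beyond the scatter is expected in this assay, a number 18.2 percentage points lower from compound 1 to compound 4 (beyond the scatter). For compound 4 the estimate in this assay is 50%, between 25% and 75%.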

Compound 4, a percentage reported as inhibition, in the whole organism at one dose (the size of the read-out at that dose, not a potency): 5.5%
The estimate for compound 4 lay 44.5 percentage points above the measured number; the whole stated range lies above it.
By their numbers in this assay, from the lowest: compound 4; then compound 3; then compound 2; then compound 1.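

With the phenyl kept in place, a group of 3 heavy atoms in place of a group of 5 heavy atoms, on a saturated chain carbon bound to an aromatic nitrogen, gives a number 62.7 percentage points lower from compound 1 to compound 4 (beyond the scatter) in this assay at the one dose given. This gives the chain its first single-place step in the series, so the phenyl alone does not hold the read-out in compound 4, and the group on the chain matters as well. No evidence at hand accounts for this step.

The entering group differs from the leaving one in both chain length and the methyl on nitrogen, so the compounds shown do not separate these two changes. Still open, from the compounds shown here alone, is how a longer chain, an amine or a carboxylic acid in place of the group of 5 heavy atoms would read out.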